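This account rests on a few compounds, and the source may have more. Where it says the series, first, only, none or still open, it means among the compounds named here.

Measured compounds:

Compound 1, `c1ccc(C2CCCCN2C2CCN(CCCc3c[nH]c4ccc(-n5cnnc5)cc34)CC2)cc1`, in an assay on CHO cells for displacement of a labelled ligand from 5-hydroxytryptamine receptor 1B (Homo sapiens) (on this read-out lower numbers stand for stronger inhibition and higher numbers for weaker inhibition), compound 1 gives 410 nM.
Compound 2, `CN(Cc1cccs1)C1CCN(CCCc2c[nH]c3ccc(-n4cnnc4)cc23)CC1`, in this assay compound 2 gives 140 nM.

Of the two numbers in hand, compound 2 has the lower one; compound 1 gives a higher number, and the gap between them is beyond the usual scatter. Going by the values given here, no step between measured compounds that differ in one place has been recorded, so there is no directly comparable pair to lean on.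

Compound 3, `c1ccc(NCC2CCN(CCCc3c[nH]c4ccc(-n5cnnc5)cc34)CC2)nc1`, has not yet been measured in this assay. It differs from compound 2 in one place: ((pyridin-2-yl)amino)methyl in place of methyl((thiophen-2-yl)methyl)amino on a saturated ring carbon. Both compounds keep the shared core of compound 2 unchanged.

With nothing measured on either side of this change, the expectation for compound 3 rests only on compound 2 and on the size of the gap to compound 1. Compound 3 is expected to give a number somewhat higher than compound 2, a step that may be within or just beyond the scatter: a 1.9-fold higher number from compound 2 to compound 3 (0.27 log units; within the scatter). The estimate for compound 3 is 260 nM, with a plausible range from 80 nM to 900 nM.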

Compound 3, half-maximal inhibitory concentration: 3.3 nM
Beside the measured number, compound 3's estimate is 79-fold (1.90 log units) above it; measured number outside the range, below it.
By their numbers in this assay, from the lowest: compound 3; then compound 2; then compound 1.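

In this assay, the saturated ring carbon three ring bonds from the ring nitrogen proves highly sensitive to what it carries: ((pyridin-2-yl)amino)methyl in place of methyl((thiophen-2-yl)methyl)amino gives a 42-fold lower number from compound 2 to compound 3 (1.63 log units; beyond the scatter), a large step and the only single-place change shown. The two groups match in heavy-atom count and in hydrogen-bond acceptors, and they differ in their aromatic ring, in a nitrogen where the other has a sulfur, and in the hydrogen-bond donor that enters, so a step of this size does not require any change in the heavy-atom count of the group. No measurement at hand bears on what lies behind this step.

The compounds shown leave open which of these differences carries the step, as a ((pyridin-2-yl)(methyl)amino)methyl group would remove the amine hydrogen and a (phenylamino)methyl group would remove the pyridine nitrogen, each leaving the rest in place. They also leave open whether a ((thiophen-2-yl)amino)methyl group on the same carbon would come close to compound 3 at 3.3 nM, which would show how much depends on the six-membered ring itself.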